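From Compound 3 to Compound 4: An Antiproliferative Estimate

The source may hold more compounds than are shown below. What is called first, only, known or untested is meant among the compounds shown, and "the series" means these compounds.

Compound 1, `COc1ccccc1NC(=O)c1ccnc2cc(Br)ccc12`: in a functional assay on KYSE-70 cells for antiproliferative activity against KYSE-70 cell line (Homo sapiens), read by MTT assay, with a stated time of 72 h (on this read-out higher numbers stand for weaker inhibition and lower numbers for stronger inhibition), compound 1 gives > 20000 nM, which is a limit of the assay rather than a number.
Compound 2, `O=C(Nc1ccc(F)cc1)c1ccnc2cc(Br)ccc12`: in this assay compound 2 gives > 20000 nM, again a limit and not a number.
Compound 3, `O=C(Nc1cccc(F)c1)c1cc(=O)[nH]c2cc(-c3ccc(F)cc3)ccc12`: in this assay compound 3 gives 3300 nM.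

Among the three measured compounds, compound 3 is the only one for which a number is reported; the other two sit at the limit of > 20000 nM in this assay, at which 2 of the 3 values shown sit, so all that can be said is that compound 3 falls inside the range the assay can resolve while compounds 1 and 2 do not. For the measured compounds named here, no two measured compounds differ in just one place, so no measured step is available to lean on.

Compound 4, `Cc1cc(-c2ccc3c(C(=O)Nc4cccc(F)c4)cc(=O)[nH]c3c2)c(C)cc1F`, has not yet been measured. It differs from compound 3 by 4-fluoro-2,5-dimethylphenyl in place of 4-fluorophenyl on an aromatic carbon. Going by the values given here, with no measured step of any kind to compare against, the expectation for this change is cautious: compound 4 is expected to land within the usual scatter of compound 3, a step of a 1.3-fold lower number from compound 3 to compound 4 (0.12 log units; within the scatter). In this assay compound 4 is estimated at 2500 nM, with a likely range from 700 nM to 9000 nM.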

Compound 4, half-maximal inhibitory concentration: > 20000 nM
Compound 4: no number, only a limit; the forecaster's own chance of this, stated with the estimate: 10%; middle value at least 8.0-fold (0.90 log units) from the limit.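

For the compounds shown here, on the aromatic carbon that carries the aryl group, the two extra methyl groups of 4-fluoro-2,5-dimethylphenyl are not a neutral swap for 4-fluorophenyl in this assay, since this single change gives the first measured step (an at least 6.0-fold higher number from compound 3 to compound 4 (0.78 log units; beyond the scatter)). The earlier compounds shown here could not show this, as no two of them differed in just one place, so nothing was yet known about how sensitive this position is to change. The step is only a minimum, because compound 4 gives a limit and not a number: the limit of > 20000 nM in this assay, at which 3 of the 4 values shown sit.

Compound 3 therefore remains the only compound with a number to compare against, and the shown compounds cannot tell whether one of the two methyl groups alone would account for the loss, or why the loss occurs at all. As far as these compounds go, it also remains open how this position would respond to a smaller or different group, such as a plain phenyl ring with no fluorine, a single methyl on the ring, or a phenyl ring carrying an amine or a carboxylic acid.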